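The source may hold more compounds than are shown below. What is called first, only, known or untested is meant among the compounds shown, and "the series" means these compounds.

Working notes on the series. In an assay on LtK cells with ATP-sensitive inward rectifier potassium channel 11 (Homo sapiens) as the target (on this read-out lower numbers stand for an effect already at smaller amounts and higher numbers for an effect only at larger amounts of compound), compound 1 `CCCC(=O)Nc1c(C(O)(C(F)(F)F)C(F)(F)F)ccc2ccccc12` gives 131 nM. Compound 2 `COc1cccc(C(=O)Nc2c(C(O)(C(F)(F)F)C(F)(F)F)ccc3ccccc23)c1` gives 185 nM in this assay. For the measured compounds named here, the only measured step, a 1.4-fold higher number from compound 1 to compound 2 (0.15 log units; within the scatter), carries 3-methoxyphenyl in place of propyl on a carbonyl carbon. On the numbers at hand compound 2 stands beside compound 1, the gap between them being within the scatter, so neither is set apart from the other.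

Going by the values given here, compound 3 `O=C(Nc1c(C(O)(C(F)(F)F)C(F)(F)F)ccc2ccccc12)c1cccs1` is not yet measured in this assay. thiophen-2-yl in place of 3-methoxyphenyl on a carbonyl carbon The step from compound 1 to compound 2 bears on it only loosely: it shows that an aromatic ring on the carbonyl carbon in place of propyl leaves the number where it was, but an exchange of one aromatic ring for another on that carbon has no precedent among the measured compounds. Nothing shown supports a step in either direction beyond the scatter. Compound 3 is therefore expected at 200 nM, with a range of 80 nM to 500 nM. The expected step is a 1.1-fold higher number from compound 2 to compound 3 (0.03 log units; within the scatter), essentially none.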

Compound 3, half-maximal effective concentration: 12 nM
The estimate for compound 3 lay 17-fold (1.22 log units) above the measured number; the measured number lies below the stated range.
By their numbers in this assay, from the lowest: compound 3; then compounds 1 and 2 (each within the scatter of the next).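

On the carbonyl carbon of the amide, the earlier pair showed only that propyl and 3-methoxyphenyl give numbers within the scatter of each other, whereas this assay now shows a strong response at this position, with thiophen-2-yl in place of 3-methoxyphenyl giving a 15-fold lower number from compound 2 to compound 3 (1.19 log units; beyond the scatter). Thiophen-2-yl in place of propyl gives an 11-fold lower number from compound 1 to compound 3 (1.04 log units; beyond the scatter), so the low number goes with thiophen-2-yl and not with an aromatic ring on that carbon as such: compound 2 also carries an aromatic ring there and stands within the scatter of compound 1. Nothing available accounts for why thiophen-2-yl stands apart from the other two groups.

The compounds shown leave open which part of the exchange carries the step, as the methoxy group, the ring size and the sulfur atom all differ at once; an unsubstituted phenyl, a furan-2-yl or a thiophen-3-yl on the same carbonyl carbon would separate these. Also open, as far as these compounds go, is whether the low number survives a methyl group or a chlorine atom on the thiophene ring.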